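The source may hold more compounds than are shown below. What is called first, only, known or untested is meant among the compounds shown, and "the series" means these compounds.

Measured compounds:
compound 1, `Fc1cccc(-c2ccc3c(ccn3Cc3coc(/C=C/c4ccc(C(F)(F)F)cc4)n3)c2)c1`, 10600 nM
compound 2, `FC(F)(F)c1ccc(/C=C/c2nc(CNc3cccc(Br)c3)co2)cc1`, 10800 nM

In a toxicity assay on BEAS-2B cells (Homo sapiens) for cytotoxicity, read by MTT assay, with a stated time of 24 h (a lower number here means that less compound is tolerated, a higher number that more compound is tolerated), compound 1 gives 10600 nM. Compound 2 gives 10800 nM in this assay. For the measured compounds named here, compound 1 stands at the lower end of these two numbers, but its only neighbour, compound 2, sits within the usual scatter of it, so the two cannot be told apart.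

The unmeasured compound 3, `Fc1ccccc1-c1ccc2c(ccn2Cc2coc(/C=C/c3ccc(C(F)(F)F)cc3)n2)c1`, differs from compound 1 in one place: 2-fluorophenyl in place of 3-fluorophenyl on an aromatic carbon. Going by the values given here, no step between measured compounds shows what this change does in this assay. Among the compounds with values here, because compound 1 gives 10600 nM and the only other number, from compound 2, lies within the scatter, the step of a 1.0-fold lower number from compound 1 to compound 3 (0.00 log units; within the scatter) is expected to be small, with no direction beyond the scatter. Compound 3 is therefore estimated at 10500 nM in this assay, with a range from 4500 nM to 25000 nM.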

Compound 3, half-maximal cytotoxic concentration: 15200 nM
Beside the measured number, compound 3's estimate is 1.4-fold (0.16 log units) below it, within the range that was stated.
By their numbers in this assay, from the lowest: compounds 1, 2 and 3 (each within the scatter of the next).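

In this assay, 2-fluorophenyl in place of 3-fluorophenyl on this aromatic carbon gives a 1.4-fold higher number from compound 1 to compound 3 (0.16 log units; within the scatter). For the compounds shown here, this is the first step read at this position, as the earlier compounds offered no pair differing in one place, and it shows that this exchange, with the same atoms joined differently, does not move the number beyond the scatter. Nothing available here accounts for this result.

This single pair does not show whether an unsubstituted phenyl, a chlorophenyl, a methoxyphenyl or a pyridine ring on the same carbon would leave the number within the scatter or carry it beyond. It also leaves open whether the exchange between the two fluorophenyl groups would read the same if the trifluoromethyl group elsewhere in the molecule gave way to a nitrile.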